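Swapping a styryl arm for a naphthyl arm

The source may report more compounds than this note shows. Statements on the series, on what has been measured and on what is new or still open speak of the compounds shown alone.

Measured compounds:
- compound 1, `CC(=O)OC[C@H]1O[C@@H](n2cc(CN3C(=O)/C(=C\c4ccccc4)c4ccccc43)nn2)[C@H](OC(C)=O)[C@@H](OC(C)=O)[C@@H]1OC(C)=O`: 17900 nM
- compound 2, `CC(=O)OC[C@H]1O[C@@H](n2cc(CN3C(=O)/C(=C\C=C\c4ccccc4)c4ccccc43)nn2)[C@H](OC(C)=O)[C@@H](OC(C)=O)[C@@H]1OC(C)=O`: 58400 nM
- compound 3, `CC(=O)OC[C@H]1O[C@@H](n2cc(CN3C(=O)/C(=C/C=C/c4ccccc4)c4ccccc43)nn2)[C@H](OC(C)=O)[C@@H](OC(C)=O)[C@@H]1OC(C)=O`: > 100000 nM

In a functional assay on A549 cells (Homo sapiens) for cytotoxicity, read by sulforhodamine B assay, with a stated time of 48 h (a lower number here means a stronger inhibitor, a higher number a weaker inhibitor), compound 2 gives 58400 nM, the higher of the two numbers that were obtained; compound 1 gives 17900 nM. Compound 3 reaches only the limit of this assay (the limit of > 100000 nM in this assay, at which 1 of the 3 values shown sits), so for it no number is known. Compound 4, `CC(=O)OC[C@H]1O[C@@H](n2cc(CN3C(=O)/C(=C\c4ccc5ccccc5c4)c4ccccc43)nn2)[C@H](OC(C)=O)[C@@H](OC(C)=O)[C@@H]1OC(C)=O`, differs from compound 2 in one place: naphthalen-2-yl in place of 2-phenylethenyl on a double-bonded chain carbon bound to a double-bonded ring carbon.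

Among the compounds with values here, the one measured step that speaks to this change is a 3.3-fold higher number from compound 1 to compound 2 (0.51 log units; beyond the scatter), where the extra ethenyl link made the number rise. Compound 4 removes that link again but carries a second aromatic ring in its place, so its aryl group is larger than the phenyl of compound 1. The step of an at least 1.7-fold higher number from compound 2 to compound 3 (0.23 log units; that floor lies within the scatter) concerns drawn geometry only the fact that compounds 2 and 3 differ only in the configuration as drawn and does not bear on the exchange of groups.

The number for compound 4 is therefore expected to fall somewhat, landing between compound 1 and compound 2, with an expected step of a 2.1-fold lower number from compound 2 to compound 4 (0.32 log units; beyond the scatter). The estimate for compound 4 in this assay is 28000 nM, within the range 9000 nM to 85000 nM.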

Compound 4, half-maximal inhibitory concentration: 62200 nM
Estimate against measurement, compound 4: 2.2-fold (0.35 log units) below; the range from low to high includes it.
By their numbers in this assay, from the lowest: compound 1; then compounds 2 and 4 (each within the scatter of the next). At a limit, above all of these: compound 3.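

In this assay, exchanging 2-phenylethenyl for naphthalen-2-yl on a double-bonded chain carbon bound to a double-bonded ring carbon gives a 1.1-fold higher number from compound 2 to compound 4 (0.03 log units; within the scatter) and so the two groups cannot be told apart here. Against phenyl at the same place, naphthalen-2-yl gives a 3.5-fold higher number from compound 1 to compound 4 (0.54 log units; beyond the scatter) and so losing the ethenyl link does not by itself bring back the number of compound 1 when a second aromatic ring comes in. The data shown offer no explanation for this result.

Going by these compounds, whether a phenyl ring carrying a methoxy group or an amine, or a pyridin-3-yl ring, would match compound 1 or compounds 2 and 4 remains open. Also open, on these data alone, is how compound 4 would compare with its counterpart of the other double-bond geometry.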